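The compounds below may be only part of what the source reports. "The series", "measured", "known", "first", "only" and "open" are said of these compounds alone.

Working notes on the series, read in a functional assay on CHO cells with adenosine receptor A1 (Homo sapiens) as the target, read by cAMP accumulation and immunoassay, with a stated time of 6 min, tested at 10 uM; on this read-out lower numbers stand for a stronger effect and higher numbers for a weaker effect at the one concentration tested.

Three compounds carry a shared core with different groups on an amine nitrogen in a ring. Compound 1 `CC(C)N1CCN(Cc2csc(N)c2C(=O)c2ccc(Cl)cc2)CC1` gives -7.4%. Compound 2 `Nc1scc(CN2CCN(c3ccc(F)cc3Cl)CC2)c1C(=O)c1ccc(Cl)cc1` gives -70%. Compound 3 `Nc1scc(CN2CCN(c3cccc4ccccc34)CC2)c1C(=O)c1ccc(Cl)cc1` gives -21% and stands second highest of the three numbers, nearest to compound 1 and furthest from compound 2.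

The measured steps: a number 62.6 percentage points lower from compound 1 to compound 2 (beyond the scatter), a number 13.6 percentage points lower from compound 1 to compound 3 (beyond the scatter) and a number 49 percentage points higher from compound 2 to compound 3 (beyond the scatter).

Compound 4 `Nc1scc(CN2CCN(c3ccc(F)c(F)c3)CC2)c1C(=O)c1ccc(Cl)cc1` is not yet measured. It differs from compound 3 in one place: 3,4-difluorophenyl in place of naphthalen-1-yl on an amine nitrogen in a ring. Among the measured compounds shown here, the step that bears most on this change is the one between compound 2 and compound 3, a large step in which a halogenated phenyl gave way to naphthalen-1-yl and the number rose sharply. Compound 4 returns to a halogenated phenyl, so the reverse direction is expected: a large fall, though 3,4-difluorophenyl is not the same group as 2-chloro-4-fluorophenyl, so the full size of that step need not be reached. The expected step is a number 29 percentage points lower from compound 3 to compound 4 (beyond the scatter), and compound 4 is estimated at -50%, with a range from -80% to -15%.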

Compound 4, a percentage reported as activity, at one concentration (the size of the read-out at that concentration, not a potency): -87%
Beside the measured number, compound 4's estimate is 37 percentage points above it, outside the stated range (below it).
By their numbers in this assay, from the lowest: compound 4; then compound 2; then compound 3; then compound 1.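

In this assay the change to 3,4-difluorophenyl on an amine nitrogen in a ring gives a number 66 percentage points lower from compound 3 to compound 4 (beyond the scatter) and thus shows that the low number at this position is not confined to compound 2. Replacing 2-chloro-4-fluorophenyl gives a number 17 percentage points lower from compound 2 to compound 4 (beyond the scatter), so the two halogenated phenyls are not interchangeable here. Replacing isopropyl gives a number 79.6 percentage points lower from compound 1 to compound 4 (beyond the scatter), which leaves compound 4 with the lowest number of the four, and the halogenated phenyls of compound 2 and compound 4 both lie under naphthalen-1-yl in compound 3 and isopropyl in compound 1.

No data at hand account for these differences. Still open, going by these compounds, is where an unsubstituted phenyl, a methoxyphenyl or a cyanophenyl would fall at this position, and so whether halogens on the phenyl are needed for the low numbers at all.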